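Phenylsulfonyl in Place of Chlorobenzyl at the Ring Nitrogen

This account rests on a few compounds, and the source may have more. Where it says the series, first, only, none or still open, it means among the compounds named here.

Compound 1 `C#CCNC1CCc2c(OCCCCCCN3CCN(c4cccc5c4ccn5Cc4cccc(Cl)c4)CC3)cccc21`: > 1000 nM
Compound 2 `C#CCNC1CCc2c(OCCCCCN3CCN(c4cccc5c4ccn5S(=O)(=O)c4ccccc4)CC3)cccc21`: 163 nM
Compound 3 `C[C@H](NCc1ccc(OCCCCN2CCN(c3cccc4c3ccn4Cc3cccc(Cl)c3)CC2)cc1)C(N)=O`: > 1000 nM

In an assay on BTI cells for inhibition of Amine oxidase [flavin-containing] B (Homo sapiens), read by fluorescence, with stated times of 30 min and 1 h (on this read-out lower numbers stand for stronger inhibition and higher numbers for weaker inhibition), compound 3 gives only a limit, > 1000 nM. This is the limit of > 1000 nM in this assay, at which 2 of the 3 values shown sit, so no number is known for compound 3, only that it sits at the limit. Compound 4 `C[C@H](NCc1ccc(OCCCCN2CCN(c3cccc4c3ccn4S(=O)(=O)c3ccccc3)CC2)cc1)C(N)=O` differs from compound 3 in one place: phenylsulfonyl in place of 3-chlorobenzyl on an aromatic nitrogen. Going by the values given here, no step between two measured compounds that differ in a single place is available. The measured compounds do show the two groups side by side: compound 2, which carries the phenylsulfonyl, gives 163 nM in this assay. Compound 1, which carries the 3-chlorobenzyl, gives only a limit, > 1000 nM. These two compounds also differ in their chain length, so their values do not isolate the exchange. On that basis, compound 4 is expected to move toward stronger inhibition, with the step of an at least 2.0-fold lower number from compound 3 to compound 4 (0.30 log units; that floor lies within the scatter) expected. The estimate for compound 4 is 500 nM, expected to fall between 100 nM and 3000 nM, with a real chance that only a limit is again reported.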

Compound 4, half-maximal inhibitory concentration: > 1000 nM
Compound 4 ended at the assay's limit (the forecaster's own chance of this, stated with the estimate: 40%); middle value at least 2.0-fold (0.30 log units) away from the limit.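

Compound 3 and compound 4 both give only a limit in this assay, so no step can be read between them: the limit of > 1000 nM in this assay, at which 3 of the 4 values shown sit.

The compounds shown leave open whether phenylsulfonyl in place of 3-chlorobenzyl on the aromatic nitrogen changes inhibition at all, and by how much.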